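Swapping the heteroaryl for 2-methylphenyl on the shared core

The compounds below may be only part of what the source reports. "The series", "measured", "known", "first", "only" and "open" are said of these compounds alone.

The measured compounds and their maximal responses:
compound 1, `Cc1cccc(NC(=O)CN2CCC(c3nccs3)CC2)c1`, gives 62% in a functional assay on HEK293 cells for agonist activity at D(4) dopamine receptor (Homo sapiens), read by FLIPR; a lower number here means a smaller maximal response, a higher number a larger maximal response;
compound 2, `COc1ccccc1C1CCN(CC(=O)Nc2cccc(C)c2)CC1`, gives 43% in this assay;
compound 3, `Cc1cccc(NC(=O)CN2CCC(c3ccc(O)cn3)CC2)c1`, gives 83% in this assay.

All three share one core and differ only in the group on a saturated ring carbon. Compound 3 stands highest of the three: the step of a number 21 percentage points higher from compound 1 to compound 3 (beyond the scatter) and the step of a number 40 percentage points higher from compound 2 to compound 3 (beyond the scatter) both lie beyond the usual scatter, so compound 3 shows the largest maximal response of the set.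

Compound 4, `Cc1cccc(NC(=O)CN2CCC(c3ccccc3C)CC2)c1`, has not been measured. Against compound 3 it shows the change (2-methylphenyl in place of 5-hydroxypyridin-2-yl on a saturated ring carbon).

Among the compounds with values here, two measured steps bear on this change. The step of a number 40 percentage points higher from compound 2 to compound 3 (beyond the scatter) shows that replacing 2-methoxyphenyl with 5-hydroxypyridin-2-yl raised the response by a large amount; the change to compound 4 runs the opposite way, from 5-hydroxypyridin-2-yl to a six-membered aromatic ring of carbon only. The step of a number 21 percentage points higher from compound 1 to compound 3 (beyond the scatter) points the same direction, with a modest size. Compound 4 is therefore expected to give a markedly lower response than compound 3, an estimated step of a number 38 percentage points lower from compound 3 to compound 4 (beyond the scatter) in this assay.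

For compound 4 the expected value in this assay is 45%, estimated to lie between 25% and 68%.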

Compound 4, largest response reached (reported as efficacy), in percent of the reference or control that the assay uses: 43%
Estimate against measurement, compound 4: 2 percentage points above; measured number inside the range.
By their numbers in this assay, from the lowest: compounds 2 and 4 (each within the scatter of the next); then compound 1; then compound 3.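

In this assay, methyl in place of methoxy on an aromatic carbon gives no change at the digits printed from compound 2 to compound 4 (within the scatter) and so separates the two groups with a six-membered aromatic ring of carbon only no further: 2-methylphenyl and 2-methoxyphenyl cannot be told apart here. The steps of a number 40 percentage points lower from compound 3 to compound 4 (beyond the scatter) and a number 19 percentage points lower from compound 1 to compound 4 (beyond the scatter) now show, with a second carbon-only ring, that among these four compounds the two with a hetero atom in the ring on the saturated ring carbon both give larger maximal responses than the two without one, and no compound shown goes against this. Nothing measured here accounts for this difference.

The compounds shown leave the ring nitrogen and the hydroxyl of 5-hydroxypyridin-2-yl unseparated, as the change to 2-methylphenyl removes both in one step and brings in a methyl as well. As far as these compounds go, how a plain pyridin-2-yl, a hydroxyphenyl or an aminopyridinyl group on this saturated ring carbon would compare also remains open.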